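A few compounds are considered here, and "the series" means these few. Any claim that something is new, unique, unknown or untested is made for them only; others in the source may bear on it.

Measured in a functional assay on HCT-116 cells (Homo sapiens) for cytotoxicity; on this read-out lower numbers stand for stronger inhibition and higher numbers for weaker inhibition:
Compound 1 `[O-]/[N+](=C\c1cc2ccccc2nc1SCc1ccccc1)c1ccccc1`: 450 nM
Compound 2 `COc1nc2ccccc2cc1/C=[N+](\[O-])c1ccccc1`: 450 nM
Compound 3 `Cc1ccc2nc(SCc3ccccc3)c(/C=[N+](\[O-])c3ccccc3)cc2c1`: 450 nM

Compound 2, at 450 nM, stands level with the other two compounds at the digits shown, so the series has no spread so far. The next compound to be read in this assay is compound 4 `CSc1nc2ccccc2cc1/C=[N+](\[O-])c1ccccc1`. It carries methylsulfanyl in place of methoxy on an aromatic carbon next to the ring nitrogen: methylsulfanyl in place of methoxy on an aromatic carbon.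

Going by the values given here, two measured steps bear on this. The closer one is no change at the digits printed from compound 1 to compound 2 (within the scatter), where methoxy replaces benzylsulfanyl at the place now being changed. Even that exchange of a much larger group left the read-out flat. The other is no change at the digits printed from compound 1 to compound 3 (within the scatter), with methyl in place of hydrogen on an aromatic carbon, and it was flat as well. Three compounds are thin evidence, and none of them carries the methylsulfanyl group, but no step beyond the scatter is expected and no direction can be favoured.

The expected step is no change at the digits printed from compound 2 to compound 4 (within the scatter). For compound 4 the estimated value is 450 nM, with an expected range of 220 nM to 900 nM.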

Compound 4, half-maximal inhibitory concentration: 450 nM
Beside the measured number, compound 4's estimate shows no gap at the digits printed; the range from low to high includes it.
By their numbers in this assay, from the lowest: compounds 1, 2, 3 and 4 (each within the scatter of the next).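

In this assay, methylsulfanyl in place of methoxy on the aromatic carbon next to the ring nitrogen gives no change at the digits printed from compound 2 to compound 4 (within the scatter), so the exchange of oxygen for sulfur in a group of the same heavy-atom count leaves the read-out flat here. Hydrogen in place of phenyl on the saturated chain carbon bound to sulfur gives no change at the digits printed from compound 1 to compound 4 (within the scatter), so with the sulfur link kept, the phenyl of the benzylsulfanyl group can go with no change in the read-out. No supporting data are available to account for this flatness.

On these data alone, whether an amine or a carboxylic acid at this place, or a longer chain on the sulfur, would move the read-out stays open. As far as these compounds go, the group of 9 heavy atoms is the same in all four compounds, so its part in the read-out also stays open.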